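Swapping the biaryl substituent in a thromboxane receptor antagonist series

The source may report more compounds than this note shows. Statements on the series, on what has been measured and on what is new or still open speak of the compounds shown alone.

Measured compounds:
Compound 1, `O=C(O)CC/C=C\CO[C@H]1[C@@H](OCc2ccc(-c3ccccc3CO)cc2)CC[C@@H]1N1CCCCCC1`: 1.59 nM
Compound 2, `O=C(O)CC/C=C\CO[C@H]1C(OCc2ccc(-c3ccc(CO)cc3)cc2)CC[C@@H]1N1CCCCCC1`: 3.16 nM
Compound 3, `CS(=O)(=O)Nc1ccccc1-c1ccc(CO[C@H]2CC[C@H](N3CCCCCC3)[C@H]2OC/C=C\CCC(=O)O)cc1`: 6.31 nM

In a functional assay on blood for antagonist activity at thromboxane A2 receptor (Homo sapiens) (a lower number here means tighter binding, a higher number weaker binding), compound 3 gives the highest number of the measured set. Its nearest neighbour is compound 2, whose value lies within the usual scatter of it, while the gap to compound 1 is beyond the scatter, as the step of a 4.0-fold higher number from compound 1 to compound 3 (0.60 log units; beyond the scatter) shows. Compound 4, `O=C(O)CC/C=C\CO[C@H]1[C@@H](OCc2ccc(-c3ccc(CO)cc3)cc2)CC[C@@H]1N1CCCCCC1`, has not yet been measured. It differs from compound 3 by 4-(hydroxymethyl)phenyl in place of 2-(methanesulfonamido)phenyl on an aromatic carbon. Among the measured compounds shown here, the one measured step that bears on this change is a 4.0-fold higher number from compound 1 to compound 3 (0.60 log units; beyond the scatter), where a methanesulfonamido group replaced a hydroxymethyl group and the number rose modestly; compound 4 runs that exchange backwards, but with the hydroxymethyl group now para to a large group, as in compound 2. Because compound 2 gives 3.16 nM in this assay, compound 4 is expected to land close to it. The estimated step of a 2.1-fold lower number from compound 3 to compound 4 (0.32 log units; beyond the scatter) therefore points to a somewhat lower number, and compound 4 is expected to give about 3 nM, within the range 1.2 nM to 8 nM.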

Compound 4, dissociation constant: 3.98 nM
The estimate for compound 4 lay 1.3-fold (0.12 log units) below the measured number; measured number inside the range.
By their numbers in this assay, from the lowest: compounds 1, 2, 4 and 3 (each within the scatter of the next, the first and the last beyond it).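

Moving from 2-(hydroxymethyl)phenyl to 4-(hydroxymethyl)phenyl gives a 2.5-fold higher number from compound 1 to compound 4 (0.40 log units; beyond the scatter), so the place of the hydroxymethyl group on this ring shows in the number. Exchanging 2-(methanesulfonamido)phenyl for 4-(hydroxymethyl)phenyl gives only a 1.6-fold lower number from compound 3 to compound 4 (0.20 log units; within the scatter), which does not separate these two compounds, whereas the methanesulfonamido and hydroxymethyl groups were separated by a 4.0-fold higher number from compound 1 to compound 3 (0.60 log units; beyond the scatter) when both stood in the same place. The pair that shares all atoms and bonds shows a 1.3-fold higher number from compound 2 to compound 4 (0.10 log units; within the scatter), so no effect of configuration can be read from it, and one limit applies to that comparison: the fact that one of compounds 2 and 4 is drawn with a defined configuration and the other without, at the place where they differ.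

The compounds shown leave open how a carboxylic acid or an amine in place of hydroxymethyl on this ring would read in this assay. They also leave open whether a longer chain carrying the hydroxyl group would follow the same difference between the two places.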